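A few compounds are considered here, and "the series" means these few. Any claim that something is new, unique, unknown or untested is made for them only; others in the source may bear on it.

Compound 1 `C=C[C@@]1(O)[C@@H](CO)O[C@@H](n2ccc(N)nc2=O)[C@@H]1O`: 74300 nM in a functional assay on KB cells (Homo sapiens), read by MTT assay; a lower number here means a stronger inhibitor, a higher number a weaker inhibitor.
Compound 2 `O=c1ccn([C@@H]2O[C@H](CO)[C@](O)(C3CC3)[C@H]2O)c(=O)[nH]1`: > 350000 nM in this assay, a limit of the assay rather than a number.

Compound 1 thus holds the only real number shown here. Compound 2 sits at the limit and gives no number. Compound 3 `Nc1ccn([C@@H]2O[C@H](CO)[C@](O)(C3CC3)[C@H]2O)c(=O)n1` has not been measured yet; it differs from compound 1 by cyclopropyl in place of vinyl on a saturated ring carbon. Among the measured compounds shown here, no step between two measured compounds covers this change, so the expectation is rough. Compound 3 is expected to be somewhat weaker, a step of a 2.0-fold higher number from compound 1 to compound 3 (0.31 log units; beyond the scatter) in this assay, modest but beyond the usual scatter. The estimate for compound 3 is 150000 nM, with a range from 40000 nM to 500000 nM.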

Compound 3, half-maximal inhibitory concentration: > 350000 nM
Compound 3: only a limit was reported; the forecaster's own chance of this, stated with the estimate: 40%; middle value at least 2.3-fold (0.36 log units) from the limit.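

Within this assay the swap of vinyl for cyclopropyl on this saturated ring carbon gives an at least 4.7-fold higher number from compound 1 to compound 3 (0.67 log units; beyond the scatter) and so is not a neutral exchange. Among the compounds shown here, this is the first direct comparison at this position, and activity on these cells does not survive the change. The step is only a minimum because the value of compound 3 is a limit: the limit of > 350000 nM in this assay, at which 2 of the 3 values shown sit.

On these data alone, how far compound 3 truly lies from compound 1 stays open. Also open, as far as these compounds go, is whether an ethyl or ethynyl group on this carbon would keep the activity of compound 1.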